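The source may hold more compounds than are shown below. What is called first, only, known or untested is meant among the compounds shown, and "the series" means these compounds.

Working notes on the series. In a functional assay on HEL cells (Homo sapiens) for cytotoxicity (a lower number here means that less compound is tolerated, a higher number that more compound is tolerated), compound 1, `CCCCCCC#Cc1cc2cn([C@@H]3O[C@H](CO)[C@@H](O)[C@H]3O)c(=O)nc2o1`, gives > 133000 nM, and this value is a limit. Compound 2, `CCCCC#Cc1cc2cn([C@H]3C[C@H](O)[C@@H](CO)O3)c(=O)nc2o1`, gives > 150000 nM, also a limit. Compound 2 therefore has no numeric value, and neither of the two measured compounds gives a number that could fix its place in the series. Compound 3, `CCCCCCC#Cc1cc2cn([C@H]3C[C@H](O)[C@@H](CO)O3)c(=O)nc2o1`, is reached from compound 2 by one change: ethyl in place of hydrogen on a saturated chain carbon, four bonds along the chain from a triple-bonded carbon. For the measured compounds named here, no measured step is available to size this change in this assay. Compound 3 is expected to end up as a limit as well, with no shift beyond the scatter. The estimate for the change is an at least 1.0-fold lower number from compound 2 to compound 3 (0.02 log units; that floor lies within the scatter), an expected step of no clear direction. For compound 3 the expected value is 140000 nM, with an estimated range of 60000 nM to 300000 nM.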

Compound 3, half-maximal cytotoxic concentration: 138000 nM
Compound 3: the middle estimate sits 1.0-fold (0.01 log units) above what was measured; low and high end bracket the measured number.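

In this assay, for the compounds shown here, compound 3 gives 138000 nM, the first actual number, so this chain position now has a measured reference point. The change of ethyl in place of hydrogen on a saturated chain carbon, four bonds along the chain from a triple-bonded carbon, reads as an at least 1.0-fold lower number from compound 2 to compound 3 (0.03 log units; that floor lies within the scatter), and only this floor can be read: the limit of > 150000 nM in this assay, at which 1 of the 3 values shown sits. The step of hydrogen in place of hydroxy on a saturated ring carbon cannot be read, because compound 1 stands at a limit: the limit of > 133000 nM in this assay, at which 1 of the 3 values shown sits.

The compounds shown leave open how far the number in this assay would move with a longer chain or an amine in place of ethyl at this position. From the compounds shown here alone, the true size of both steps also remains open.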